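The compounds below may be only part of what the source reports. "The series", "measured", "known", "first", "only" and "open" are said of these compounds alone.

In a toxicity assay on L6 cells (Rattus norvegicus) for cytotoxicity, read by resazurin assay, with a stated time of 72 h (a higher number here means a weaker inhibitor, a lower number a stronger inhibitor), compound 1 `COCO[C@H](c1ccc(OC)c(OC)c1)[C@@H](C)Oc1ccc(Br)cc1OC` gives 50.6 ug/mL. Compound 3 `C/C=C/c1ccc(O[C@H](C)[C@@H](OCOC)c2ccccc2)c(OC)c1` gives 52.3 ug/mL, which is within the scatter of compound 1, so the two cannot be told apart. Compound 2 `COc1cc(-c2ccccc2)ccc1O[C@H](C)[C@@H](O)c1ccccc1` gives 11.2 ug/mL, a clearly lower number than compound 1 and so a stronger inhibitor.

The next compound to be measured is compound 4 `COc1ccc([C@@H](O)[C@@H](C)Oc2ccc(Br)cc2OC)cc1OC`, which differs from compound 1 in one place: hydrogen in place of methoxymethyl on an oxygen on a saturated carbon. In words, hydrogen replaces methoxymethyl on an oxygen on a saturated carbon, turning methoxymethoxy into hydroxy.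

Within the data shown here, no measured pair isolates this change, so the expectation is loose. Compound 2 also carries a hydroxy and gives 11.2 ug/mL, while compound 3 keeps the methoxymethoxy and gives 52.3 ug/mL. However, these two differ elsewhere as well. A moderate move toward a lower number in this assay therefore seems likely, with no change beyond the scatter still possible. The expected step is a 1.7-fold lower number from compound 1 to compound 4 (0.23 log units; within the scatter). For compound 4, the estimated value is 30 ug/mL, with an expected range of 12 ug/mL to 70 ug/mL.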

Compound 4, half-maximal inhibitory concentration: 20.9 ug/mL
The estimate for compound 4 lay 1.4-fold (0.16 log units) above the measured number; the range from low to high includes it.
By their numbers in this assay, from the lowest: compounds 2 and 4 (each within the scatter of the next); then compounds 1 and 3 (each within the scatter of the next).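

Replacing the methoxymethyl on the oxygen on a saturated carbon with hydrogen, which turns methoxymethoxy into hydroxy, gives a 2.4-fold lower number from compound 1 to compound 4 (0.38 log units; beyond the scatter) in this assay for this modest change. This is the only pair shown that differs in this one place alone, so the change can now be read directly rather than inferred from compounds that also differ elsewhere. On the core of compound 1, the free hydroxy goes with a lower number and so a stronger inhibitor, but no measurement shown here accounts for the shift.

From the compounds shown here alone, whether a methyl ether or an acetyl ester on this oxygen would give a number nearer to that of compound 1 or compound 4 stays open. So does whether the same change would give a similar step on other cores, such as those of compound 2 and compound 3.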